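From an aryl sulfone to a piperazine sulfonamide

The compounds below may be only part of what the source reports. "The series", "measured", "known", "first", "only" and "open" are said of these compounds alone.

Compound 1 `O=C(NCc1ccc(S(=O)(=O)c2cccc(C(F)(F)F)c2)cc1)N1Cc2ccncc2C1` carries a 3-(trifluoromethyl)phenyl on its sulfonyl sulfur. Going by the values given here, in an assay on isolated protein for inhibition of Nicotinamide phosphoribosyltransferase (Homo sapiens), read by mass spectrometry, with stated times of 15 min and 30 min (a lower number here means a stronger inhibitor, a higher number a weaker inhibitor), compound 1 gives 8 nM, the lowest of the two numbers measured so far. Its nearest neighbour is compound 2 `CC(C)n1cc(S(=O)(=O)c2ccc(CNC(=O)N3Cc4ccncc4C3)cc2)cn1`, which in this assay gives 20 nM; the step of a 2.5-fold higher number from compound 1 to compound 2 (0.40 log units; beyond the scatter) shows that exchanging the aryl group for 1-isopropyl-1H-pyrazol-4-yl already weakens inhibition modestly. Compound 3 `CN1CCN(S(=O)(=O)c2ccc(CNC(=O)N3Cc4ccncc4C3)cc2)CC1` goes further: 4-methylpiperazin-1-yl in place of 3-(trifluoromethyl)phenyl on a sulfonyl sulfur. Among the compounds with values here, the only measured step that bears on this change is a 2.5-fold higher number from compound 1 to compound 2 (0.40 log units; beyond the scatter), where the group on the sulfonyl sulfur was likewise exchanged; here the entering ring is non-aromatic and brings a hydrogen-bond acceptor, a larger departure from compound 1 than compound 2 made. A larger weakening is therefore expected, a 7.5-fold higher number from compound 1 to compound 3 (0.88 log units; beyond the scatter). Compound 3 is estimated to give 60 nM in this assay, with a range from 15 nM to 300 nM.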

Compound 3, half-maximal inhibitory concentration: 38 nM
Compound 3: the middle estimate sits 1.6-fold (0.20 log units) above what was measured, and the stated range covers the measured number.
By their numbers in this assay, from the lowest: compound 1; then compounds 2 and 3 (each within the scatter of the next).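

In this assay, replacing 3-(trifluoromethyl)phenyl with 4-methylpiperazin-1-yl on the sulfonyl sulfur gives a 4.8-fold higher number from compound 1 to compound 3 (0.68 log units; beyond the scatter), so inhibition weakens but is not lost when the aromatic ring at this position gives way to a non-aromatic one. Comparing the two replacement groups gives a 1.9-fold higher number from compound 2 to compound 3 (0.28 log units; within the scatter), so 1-isopropyl-1H-pyrazol-4-yl and 4-methylpiperazin-1-yl cannot be told apart here, even though one ring is aromatic and the other is not. Nothing available explains these differences.

The compounds shown leave open whether the methyl group on the piperazine matters, which a plain piperazin-1-yl group could test. They also leave open how a morpholin-4-yl ring or an open-chain dimethylamino group on the same sulfur would compare.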